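Swapping the Urea Aryl Group Once More

This account rests on a few compounds, and the source may have more. Where it says the series, first, only, none or still open, it means among the compounds named here.

The compounds share one core, shown for compound 1 as `COc1cc(Nc2ncnc3c(NC(=O)Nc4ccc(C)c(C)c4)cccc23)cc(OC)c1`, and differ only in the aryl group carried on the amide-type nitrogen of the urea. In a functional assay on RT-112 cells (Homo sapiens) for antiproliferative activity, read by MTT assay, with a stated time of 72 h (on this read-out lower numbers stand for stronger inhibition of growth and higher numbers for weaker inhibition of growth), compound 1 gives 8.8 nM. Compound 2, `COc1cc(Nc2ncnc3c(NC(=O)Nc4ccc(Cl)c(C(F)(F)F)c4)cccc23)cc(OC)c1`, gives > 20000 nM in this assay, and this is a limit of the assay rather than a number, as the limit of > 20000 nM in this assay, at which 1 of the 2 values shown sits, shows. For the measured compounds named here, the single measured step is an at least 2200-fold higher number from compound 1 to compound 2 (3.35 log units; beyond the scatter). Compound 3, `COc1cc(Nc2ncnc3c(NC(=O)Nc4ccc(Cl)cc4Cl)cccc23)cc(OC)c1`, differs from compound 2 by 2,4-dichlorophenyl in place of 4-chloro-3-(trifluoromethyl)phenyl on an amide-type nitrogen. Going by the values given here, with compound 2 at the limit, the step to compound 3 can only be bounded, and no measured step covers the entry of 2,4-dichlorophenyl itself; compound 1 shows only that a different aryl group on this nitrogen can be highly potent. Compound 3 is expected to show an at least 10-fold lower number from compound 2 to compound 3 (1.00 log units; beyond the scatter), a gain of uncertain size. The value of compound 3 is estimated at 2000 nM, within 100 nM to 20000 nM.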

Compound 3, concentration for 50% growth inhibition: 3060 nM
Estimate against measurement, compound 3: 1.5-fold (0.18 log units) below; the measured number falls inside the stated range.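

Compound 3 shows that a halogen-bearing aryl group on this nitrogen can still give a measurable value in this assay: the change to 2,4-dichlorophenyl gives an at least 6.5-fold lower number from compound 2 to compound 3 (0.81 log units; beyond the scatter). The value of compound 2 is a limit of the assay and not a number, so the true size of that step stays unknown: the limit of > 20000 nM in this assay, at which 1 of the 3 values shown sits. Even so, 2,4-dichlorophenyl does not recover what 3,4-dimethylphenyl gives, with a 350-fold higher number from compound 1 to compound 3 (2.54 log units; beyond the scatter), so both halogen-bearing aryl groups shown lie far from compound 1.

The compounds shown leave open whether the chlorine atoms, the trifluoromethyl group or the arrangement of the groups on the ring accounts for these differences. Also open, from the compounds shown here alone, is what a single methyl group, a single chlorine atom, a methoxy group or an amine on this aryl ring would give.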